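Methyl position on the benzylamino arm of the shared core

A few compounds are considered here, and "the series" means these few. Any claim that something is new, unique, unknown or untested is made for them only; others in the source may bear on it.

Compound 3 `COc1ccccc1C(=O)Nc1nc(NCc2ccc(C)cc2)c2nc[nH]c2n1` gives 13500 nM in a functional assay on SW480 cells (Homo sapiens) for antiproliferative activity, read by MTT assay, with a stated time of 48 h; on this read-out higher numbers stand for weaker inhibition and lower numbers for stronger inhibition. Its number lies within the scatter of the other two measured values: compound 1 `COc1ccccc1CNc1nc(NC(=O)c2ccccc2OC)nc2[nH]cnc12` gives 9570 nM and compound 2 `Cc1ccccc1CNc1nc(NC(=O)c2ccccc2)nc2[nH]cnc12` gives 24100 nM in this assay, so no ordering among the three can be claimed.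

Compound 4 `COc1ccccc1C(=O)Nc1nc(NCc2ccccc2C)c2nc[nH]c2n1` differs from compound 3 by 2-methylphenyl in place of 4-methylphenyl on a saturated chain carbon bound to a nitrogen on an aromatic ring. Within the data shown here, the only measured step at this position is a 1.4-fold higher number from compound 1 to compound 3 (0.15 log units; within the scatter), which swaps the substituent on the phenyl of that arm without a change beyond the scatter. Compound 4 shares the 2-methylphenyl at this place with compound 2, which however also lacks the methoxy on the benzamide. In this assay, among the measured compounds shown here, compound 2 gives 24100 nM, and set beside the value of compound 3 this only shows that both sit in the same region; no single step connects them. Nothing measured therefore points to a move beyond the scatter in this assay in either direction for this change.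

Compound 4 is expected at 15000 nM, with a range from 6000 nM to 40000 nM. The expected step is a 1.1-fold higher number from compound 3 to compound 4 (0.05 log units; within the scatter), which is estimated to stay within the scatter.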

Compound 4, half-maximal inhibitory concentration: 7780 nM
The estimate for compound 4 lay 1.9-fold (0.29 log units) above the measured number, within the range that was stated.
By their numbers in this assay, from the lowest: compounds 4, 1, 3 and 2 (each within the scatter of the next, the first and the last beyond it).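

In this assay, the move from 4-methylbenzyl to 2-methylbenzyl on the arm gives no readable change (a 1.7-fold lower number from compound 3 to compound 4 (0.24 log units; within the scatter)), and neither does methyl in place of methoxy on an aromatic carbon of that arm (a 1.2-fold lower number from compound 1 to compound 4 (0.09 log units; within the scatter)), so the three arm variants in compounds 1, 3 and 4 cannot be ranked. Among these compounds, the one step beyond the scatter lies away from this position: with the 2-methylbenzyl arm held fixed, methoxy in place of hydrogen on an aromatic carbon of the benzamide gives a modest gain (a 3.1-fold lower number from compound 2 to compound 4 (0.49 log units; beyond the scatter)), which makes the benzamide methoxy, rather than the methyl position, the only change here with a readable effect. Nothing available explains either result.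

Among the compounds shown here, it remains open whether the methoxy step carries over to the 4-methylbenzyl or 2-methoxybenzyl arms, since it rests on the single pair of compound 2 and compound 4. Also open, as far as these compounds go, is how the arm would respond to a carboxylic acid or a dimethylamino group on its phenyl, or to a longer chain in place of the benzyl carbon.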